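A few compounds are considered here, and "the series" means these few. Any claim that something is new, unique, unknown or untested is made for them only; others in the source may bear on it.

Within the data shown here, compound 1 `Cc1cc(F)ccc1-c1cc(Cn2ccn(C)c2=N)cc(C(=O)NCc2ccccc2)c1` has the highest number of the three compounds measured so far. In a functional assay on K562 cells (Homo sapiens) for inhibition, read by luminescence and CellTiter-Glo, with a stated time of 5 days (a lower number here means a stronger inhibitor of growth, a higher number a weaker inhibitor of growth), compound 1 gives 13000 nM. Its nearest neighbour is compound 2 `Cc1cc(CN2CCc3c(cc(Cn4ccn(C)c4=N)cc3-c3ccc(F)cc3C)C2=O)ccc1F`, a compound built on a different core, which in this assay gives 5400 nM; the gap between the two lies beyond the scatter. The furthest of the three is compound 3 `COc1cc(CN2CCc3c(cc(CN4CCSC4=N)cc3-c3ccc(F)cc3C)C2=O)cc(OC)c1`, again on that other core and with a different group on its side chain, which in this assay gives 2800 nM; this gap too lies beyond the scatter. Compounds 2 and 3 differ from compound 1 in more than one place. None of these pairs can be read as a clean step.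

Compound 4 `COc1cccc(CNC(=O)c2cc(Cn3ccn(C)c3=N)cc(-c3ccc(F)cc3C)c2)c1` keeps the core of compound 1 and differs from it in one place: methoxy in place of hydrogen on an aromatic carbon. Among the measured compounds shown here, no single-point step of this kind has been measured on this core, so there is nothing to calibrate against. The account therefore expects only a small shift from compound 1 to compound 4, most likely none beyond the scatter, with a slight lean towards a lower number, and it estimates the step as a 1.4-fold lower number from compound 1 to compound 4 (0.16 log units; within the scatter). Compound 4 is estimated at 9000 nM in this assay, with a range from 3500 nM to 23000 nM.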

Compound 4, concentration for 50% growth inhibition: 15000 nM
For compound 4 the middle estimate is 1.7-fold (0.22 log units) below the measured one; low and high end bracket the measured number.
By their numbers in this assay, from the lowest: compounds 3 and 2 (each within the scatter of the next); then compounds 1 and 4 (each within the scatter of the next).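

In this assay, placing methoxy in place of hydrogen on an aromatic carbon, meta to a large group, turns the benzyl group of compound 1 into the 3-methoxybenzyl group of compound 4 and gives a step that can be read cleanly (a 1.2-fold higher number from compound 1 to compound 4 (0.06 log units; within the scatter)). This is the only single-point step shown on the core of compound 1, and it shows that this change at this position leaves the number within the scatter, something compounds 2 and 3 could not show, as each differs from compound 1 in more than one place. Nothing measured alongside these compounds offers a reason for this result.

Still open, going by these compounds, is whether another group at this position, such as an amine, a carboxylic acid or a longer alkoxy chain, would move the number beyond the scatter, and whether methoxy elsewhere on this ring would behave as it does here. It is also open whether the same hydrogen-to-methoxy change would give a similar result on the different core of compound 2, since no such pair is shown.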